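This account rests on a few compounds, and the source may have more. Where it says the series, first, only, none or still open, it means among the compounds named here.

Working notes on the series. Of the compounds shown here, two carry a number so far. Compound 1 `O=C(Nc1cccc(S(=O)(=O)C2COC2)c1)c1cccnc1N1CCC2(CC1)CC2` and compound 2 `CC(C)(C)NS(=O)(=O)c1cccc(NC(=O)c2ncc(NC(C)(C)CO)nc2N2CCC3(CC2)CC3)c1` were run in an ADME assay on microsomes from liver (Mus musculus) for metabolic stability, read by LC-MS, with a stated time of 40 min, tested at 0.5 uM; a higher number here means faster removal of the compound, a lower number slower removal. In this assay compound 1 gives 385 mL.min-1.g-1, the higher of the two numbers; in this assay compound 2 gives 76 mL.min-1.g-1, a gap that lies beyond the scatter of the method. Among the compounds with values here, no single-site step between measured compounds is available, so the next compound is judged from compound 1 alone.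

Compound 3 `O=C(Nc1cccc(S(=O)(=O)C2CCCC2)c1)c1cccnc1N1CCC2(CC1)CC2` has not yet been measured in this assay. It differs from compound 1 only as follows: cyclopentyl in place of oxetan-3-yl on a sulfonyl sulfur. The shared core and the rest of the substitution are unchanged.

Within the data shown here, with no measured pair to lean on, the expectation for compound 3 is a step from compound 1 of modest size, a 1.4-fold higher number from compound 1 to compound 3 (0.15 log units; within the scatter), in the direction of faster removal, and possibly no change beyond the scatter. The estimate for compound 3 in this assay is 550 mL.min-1.g-1, with a range from 250 mL.min-1.g-1 to 1100 mL.min-1.g-1.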

Compound 3, intrinsic clearance in microsomes: > 399 mL.min-1.g-1
Compound 3: no number, only a limit; the forecaster's own chance of this, stated with the estimate: 15%; the middle value does not contradict the limit.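

In this assay compound 3 gives > 399 mL.min-1.g-1, which is a limit of the assay and not a number. Cyclopentyl in place of oxetan-3-yl on a sulfonyl sulfur gives an at least 1.0-fold higher number from compound 1 to compound 3 (0.01 log units; that floor lies within the scatter), so this change on the sulfonyl sulfur does not bring slower removal, while the true size of the step stays unknown and may or may not exceed the scatter. The reading of this step therefore rests on a floor and not on a pair of numbers: the limit of > 399 mL.min-1.g-1 in this assay, at which 1 of the 3 values shown sits.

From the compounds shown here alone, how far compound 3 lies past its limit remains open, as does whether the oxygen of oxetan-3-yl has any bearing on the number. Also open, going by these compounds, is whether an amine or a longer carbon chain on the same sulfonyl sulfur would move the number beyond the scatter.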